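Thiophene isomer swap in a small cytotoxicity series

This account rests on a few compounds, and the source may have more. Where it says the series, first, only, none or still open, it means among the compounds named here.

Measured so far in a functional assay on HCT-15 cells (Homo sapiens) for cytotoxicity, read by CCK-8 assay and cell counting, with a stated time of 2 days; a higher number here means a weaker inhibitor, a lower number a stronger inhibitor:
- compound 1 `Oc1ccc(-c2cc(-c3ccc(Cl)cc3)nc(-c3cccs3)c2)cc1` gives 6470 nM
- compound 2 `Oc1ccc(-c2cc(-c3ccc(Cl)cc3)nc(-c3ccsc3)c2)cc1` gives 6240 nM
- compound 3 `Oc1cccc(-c2cc(-c3ccsc3)nc(-c3cccc(Cl)c3)c2)c1` gives 2510 nM

Compounds 1 and 2 share one core; compound 3 has another, and the difference between the two cores is not broken down here. Within the first core the change thiophen-2-yl in place of thiophen-3-yl on an aromatic carbon gave a 1.0-fold higher number from compound 2 to compound 1 (0.02 log units; within the scatter), so the two thiophene isomers are not separated by this assay there. Compound 3 stands as the strongest inhibitor of the three, its steps to compounds 1 and 2 both lying beyond the scatter.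

Compound 4 `Oc1cccc(-c2cc(-c3cccc(Cl)c3)nc(-c3cccs3)c2)c1` is not yet measured. It arises from compound 3 by thiophen-2-yl in place of thiophen-3-yl on an aromatic carbon, the same kind of change as from compound 2 to compound 1, though the surroundings differ: there the position was meta to a 4-chlorophenyl group and a 4-hydroxyphenyl group, here it is meta to a 3-chlorophenyl group and a 3-hydroxyphenyl group. Going by the values given here, the expected step is a 1.0-fold lower number from compound 3 to compound 4 (0.00 log units; within the scatter), resting on the single earlier instance a 1.0-fold higher number from compound 2 to compound 1 (0.02 log units; within the scatter). For compound 4 the estimate in this assay is 2500 nM, between 1200 nM and 5200 nM.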

Compound 4, half-maximal inhibitory concentration: 2610 nM
Beside the measured number, compound 4's estimate is 1.0-fold (0.02 log units) below it, within the range that was stated.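

In this assay the change of thiophen-3-yl to thiophen-2-yl on the core of compound 3 gave a 1.0-fold higher number from compound 3 to compound 4 (0.02 log units; within the scatter) and so, as on the core of compound 1, did not separate the two thiophene isomers. This holds for two cores only, and it shows that the isomer swap stays silent in this assay on both, not that it would stay silent on any further core of the series. Set side by side, the two steps give no sign that the change behaves differently from one core to the other: the same change on two cores in this assay, a 1.0-fold higher number (0.02 log units; within the scatter) from compound 2 to compound 1 and a 1.0-fold higher number (0.02 log units; within the scatter) from compound 3 to compound 4, 1.0-fold (0.00 log units) apart, within the scatter of two such steps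

The compounds shown leave open what the thiophene itself contributes, since every one of them carries a thiophene and none has a furan or a plain phenyl group in that place. Also open, going by these compounds, is how the 3-chlorophenyl and 3-hydroxyphenyl groups act separately, and whether a methoxy group or an amine could stand in place of the hydroxyl.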